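The source may hold more compounds than are shown below. What is called first, only, known or untested is meant among the compounds shown, and "the series" means these compounds.

In an ADME assay on microsomes from liver (Mus musculus) for metabolic stability, read by HPLC, using NADPH, with a stated time of 60 min, tested at 1 uM, in the presence of a further agent that is not named here (on this read-out higher numbers stand for fast clearance and lower numbers for slow clearance), compound 1 `Cc1cc(-c2ncccn2)cc(C(=O)NNS(=O)(=O)c2ccccc2)c1F` gives 279 uL/min and compound 2 `Cc1cc(-c2ccccn2)cc(C(=O)NNS(=O)(=O)c2ccccc2)c1F` gives 424 uL/min. Compound 3 `Cc1cc(OC(C)C)cc(C(=O)NNS(=O)(=O)c2ccccc2F)c1` reaches a limit of this assay, > 866 uL/min, and no number is known for it.

Compound 3 therefore stands at the limit of > 866 uL/min in this assay, at which 1 of the 3 values shown sits, and it cannot be placed against compounds 1 and 2 beyond that. Compound 4 `CCOc1cc(C)cc(C(=O)NNS(=O)(=O)c2ccccc2F)c1` differs from compound 3 by hydrogen in place of methyl on a saturated chain carbon bound to an oxygen on an aromatic ring and a saturated chain carbon. Among the measured compounds shown here, the one measured step, a 1.5-fold higher number from compound 1 to compound 2 (0.18 log units; within the scatter), concerns another part of the structure and gives no guide to this change. For the measured compounds named here, with no step to lean on, the expected step of an at least 1.0-fold lower number from compound 3 to compound 4 (0.03 log units; that floor lies within the scatter) is small and of uncertain direction. Compound 4 is thus estimated at 800 uL/min, in the range 350 uL/min to 1700 uL/min, and it may again reach only the limit.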

Compound 4, intrinsic clearance in a liver preparation (reported as CLH), per the amount of preparation that the assay uses in the Mus musculus assay: > 866 uL/min
Compound 4: only a limit was reported; the forecaster's own chance of this, stated with the estimate: 55%; middle value at least 1.0-fold (0.03 log units) away from the limit.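

No step from compound 3 to compound 4 can be read in the Mus musculus assay, where each reaches a limit of the assay and not a number: the limit of > 866 uL/min in the Mus musculus assay, at which 2 of the 4 values shown sit.

In a physicochemical assay for solubility, read by nephelometry, measured as kinetic solubility, at pH 2 (on this read-out higher numbers stand for higher solubility and lower numbers for lower solubility), compound 3 gives 12.5 ug/mL and compound 4 gives 12.5 ug/mL. The compounds shown leave open whether isopropoxy to ethoxy alters clearance at all in the Mus musculus assay.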